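Chain-Extended Dicarboxylic Acids Tested on Leukaemia Cells

The compounds below may be only part of what the source reports. "The series", "measured", "known", "first", "only" and "open" are said of these compounds alone.

Compound 1 `CC1OC(OC2CCCCC2OCCCCCCCC(C(=O)O)C(=O)O)C(O)C(O)C1O` and compound 2 `CC1OC(OC2CCCCC2OCCCCCCCCC(C(=O)O)C(=O)O)C(O)C(O)C1O` were examined in a functional assay on HL-60 cells (Homo sapiens) for inhibition; on this read-out higher numbers stand for weaker inhibition and lower numbers for stronger inhibition. Compound 1 reaches only the limit of > 5000000 nM and gives no number. Compound 2 likewise reaches only the limit of > 5000000 nM. Their difference, (2,2-dicarboxyethyl in place of dicarboxymethyl on a saturated chain carbon, seven bonds along the chain from an oxygen on a saturated carbon), therefore gives a step that the two limits leave unreadable from compound 1 to compound 2, with both compounds sitting at the limit of > 5000000 nM in this assay, at which 2 of the 3 values shown sit. For the measured compounds named here, compound 3 `CC1OC(OC2CCCCC2OC(=O)NCCCC(C(=O)O)C(=O)O)C(O)C(O)C1O` gives 1000000 nM in this assay, the only number among the three. The difference between the core of compound 3 and that of compound 1 is not broken down here. Compound 4 `CC1OC(OC2CCCCC2OC(=O)NCCCCC(C(=O)O)C(=O)O)C(O)C(O)C1O` carries the same kind of change, (2,2-dicarboxyethyl in place of dicarboxymethyl on a saturated chain carbon, three bonds along the chain from an amide-type nitrogen), the surroundings differing in that it sits three bonds along the chain from an amide-type nitrogen rather than seven bonds from an oxygen on a saturated carbon. The measured step from compound 1 to compound 2 is unreadable, so nothing about its size carries over. Compound 3 at 1000000 nM is the only anchor. The expected step is a 1.5-fold higher number from compound 3 to compound 4 (0.18 log units; within the scatter). Compound 4 is estimated at 1500000 nM, between 500000 nM and 5000000 nM.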

Compound 4, half-maximal inhibitory concentration: 4000000 nM
The estimate for compound 4 lay 2.7-fold (0.43 log units) below the measured number; measured number inside the range.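

On the core of compound 3, in this assay, 2,2-dicarboxyethyl in place of dicarboxymethyl on a saturated chain carbon, three bonds along the chain from an amide-type nitrogen, gives a 4.0-fold higher number from compound 3 to compound 4 (0.60 log units; beyond the scatter). The same change on the core of compound 1 cannot be read, since both compounds there give a limit and not a number: the limit of > 5000000 nM in this assay, at which 2 of the 4 values shown sit. This leaves a single readable instance of the change, so it does not show whether the step carries from one core to the other.

The compounds shown leave open whether 3,3-dicarboxypropyl or 4,4-dicarboxybutyl would extend this step on the core of compound 3. They also leave open what an amine in place of the two carboxylic acids would give.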